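The compounds below may be only part of what the source reports. "The series", "measured", "known", "first", "only" and "open" are said of these compounds alone.

Three compounds have been measured in an assay on HEK293 cells for displacement of a labelled ligand from Neuronal acetylcholine receptor; alpha4/beta2 (Homo sapiens); a higher number here means a weaker inhibitor, a lower number a stronger inhibitor:

Compound 1, `Brc1ccc(N2CCCNCCC2)cn1`, gives 0.447 nM.
Compound 2, `c1cncc(N2CCCNCCC2)c1`, gives 0.891 nM.
Compound 3, `Oc1cc(N2CCCNCC2)cnc1I`, gives 21.9 nM.

Compound 2 stands second highest of the three numbers in this assay; its nearest neighbour is compound 1, and the gap between them, a 2.0-fold higher number from compound 1 to compound 2 (0.30 log units; within the scatter), lies within the scatter, while compound 3 sits far higher. The step to the unmeasured compound 4, `Brc1cncc(N2CCCNCCC2)c1`, is bromo in place of hydrogen on an aromatic carbon. Among the measured compounds shown here, only one measured step bears on this change: a 2.0-fold higher number from compound 1 to compound 2 (0.30 log units; within the scatter), which removes a bromo from the shared core without moving the number beyond the scatter, although the bromo of compound 1 and that of compound 4 do not sit on the same ring carbon. Putting a bromo back is therefore expected to give a step of about a 1.5-fold lower number from compound 2 to compound 4 (0.17 log units; within the scatter), no larger than the scatter, with the number perhaps a little lower. Compound 4 is estimated at 0.6 nM, within a range from 0.2 nM to 2 nM.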

Compound 4, half-maximal inhibitory concentration: 2.82 nM
Estimate against measurement, compound 4: 4.7-fold (0.67 log units) below; the measured number lies above the stated range.
By their numbers in this assay, from the lowest: compounds 1 and 2 (each within the scatter of the next); then compound 4; then compound 3.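

In this assay, a bromo on this aromatic carbon, two atoms from the ring nitrogen, is not neutral: the change gives a 3.2-fold higher number from compound 2 to compound 4 (0.50 log units; beyond the scatter) and so makes a modestly weaker inhibitor. Among the compounds shown here, earlier, the only step involving a bromo stayed within the scatter, but that bromo sat on a different ring carbon, so the effect of this group depends on where it is placed, at least in this small set: compound 1 gives 0.447 nM and compound 4 gives 2.82 nM. No measurement at hand explains why this carbon responds differently.

As far as these compounds go, whether a chloro, a methyl or an amine on this same carbon would also raise the number remains open. Compound 3 differs from these compounds in more than one place, so it cannot settle that question.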